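Replacing a Naphthyl Ring with 3-Ethylphenyl: Expected Solubility

The source may hold more compounds than are shown below. What is called first, only, known or untested is meant among the compounds shown, and "the series" means these compounds.

The measured compounds and their numbers:
Compound 1, `CCc1ccc(-c2nc3c(c(C)nn3-c3ccccc3)c(-c3ccccc3F)c2C#N)cc1`, gives 1700 nM.
Compound 2, `CCc1ccc(-c2nc3c(c(C)nn3-c3ccccc3)c(-c3ccccc3OC(F)(F)F)c2C#N)cc1`, gives 9900 nM.
Compound 3, `Cc1nn(-c2ccccc2)c2nc(-c3ccc4ccccc4c3)c(C#N)c(-c3ccccc3O)c12`, gives 1800 nM.

These values come from a physicochemical assay for solubility, read by spectrophotometry, in phosphate buffer, with a stated time of 18 h, at pH 7.4; a lower number here means a less soluble compound, a higher number a more soluble compound. Compound 3 stands second highest of the three numbers; it sits within the scatter of compound 1 and beyond the scatter below compound 2. For the measured compounds named here, the only measured step is a 5.8-fold higher number from compound 1 to compound 2 (0.77 log units; beyond the scatter), which concerns a different part of the shared core than the change now considered.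

Compound 4, `CCc1cccc(-c2nc3c(c(C)nn3-c3ccccc3)c(-c3ccccc3O)c2C#N)c1`, is not yet measured. It differs from compound 3 in this way: 3-ethylphenyl in place of naphthalen-2-yl on an aromatic carbon. Going by the values given here, no measured step touches this position. Among the compounds with values here, compounds 1 and 2 carry 4-ethylphenyl where compound 3 carries naphthalen-2-yl, but they also differ from compound 3 elsewhere, so their values show only that such compounds fall in the same broad region as compound 3. Compound 4 is therefore expected to stay near compound 3, with a step of a 1.2-fold higher number from compound 3 to compound 4 (0.09 log units; within the scatter) that is expected to lie within the scatter. The estimate for compound 4 in this assay is 2200 nM, expected between 800 nM and 6000 nM.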

Compound 4, solubility: 11000 nM
For compound 4 the middle estimate is 5.0-fold (0.70 log units) below the measured one; measured number above the stated range.
By their numbers in this assay, from the lowest: compounds 1 and 3 (each within the scatter of the next); then compounds 2 and 4 (each within the scatter of the next).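

In this assay, the aromatic carbon next to the ring nitrogen and ortho to a cyano group proves sensitive to the group it carries: 3-ethylphenyl in place of naphthalen-2-yl gives a 6.1-fold higher number from compound 3 to compound 4 (0.79 log units; beyond the scatter). For the compounds shown here, the earlier compounds offered only a step at a different part of the shared core, so this is the first measured sign that the number also responds to a change here. Nothing among the available data accounts for the rise at this position.

The single step changes two things at once, going from two aromatic rings to one and adding an ethyl group, and the compounds shown do not separate these. They also leave open whether an unsubstituted phenyl, a longer chain in place of the ethyl, or an amine on this ring would give a similarly high number.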